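Naphthalen-2-yl in Place of 4-Methoxyphenyl: Compound 4

The source may hold more compounds than are shown below. What is called first, only, known or untested is meant among the compounds shown, and "the series" means these compounds.

Among the three compounds measured in a functional assay on cells (Cancer cell lines, Homo sapiens) for cytotoxicity, read by sulforhodamine B assay, with a stated time of 48 h (on this read-out lower numbers stand for stronger inhibition of growth and higher numbers for weaker inhibition of growth), compound 2 `COc1ccc(-c2cc(-c3ccc(Cl)cc3)n(C3C(=O)Nc4ccc(Br)cc43)n2)cc1` gives 16700 nM, the highest of the three numbers. Its nearest neighbour is compound 3 `COc1ccc(-c2cc(-c3ccc(Cl)cc3)n(C3C(=O)Nc4ccc(Cl)cc43)n2)cc1`, which gives 14400 nM; the change from compound 2 to compound 3 is a 1.2-fold lower number from compound 2 to compound 3 (0.06 log units; within the scatter), a chloro in place of bromo on an aromatic carbon. Compound 1 `O=C1N=C(N2N=C(c3ccccc3)CC2c2ccccc2O)S/C1=C1/C(=O)Nc2ccccc21` gives 5370 nM, which stands beyond the scatter from compound 2.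

Compound 4 `O=C1Nc2ccc(Br)cc2C1n1nc(-c2ccc3ccccc3c2)cc1-c1ccc(Cl)cc1` differs from compound 2 by naphthalen-2-yl in place of 4-methoxyphenyl on an aromatic carbon. For the measured compounds named here, no measured step bears on this change, and the only measured step, from compound 2 to compound 3, stayed within the scatter. Compound 4 is therefore expected near compound 2, with the estimated step being a 1.4-fold lower number from compound 2 to compound 4 (0.14 log units; within the scatter). The estimate for compound 4 is 12000 nM, within 4000 nM to 40000 nM.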

Compound 4, concentration for total growth inhibition: 10500 nM
Compound 4: middle estimate off by 1.1-fold (0.06 log units), on the high side, within the range that was stated.
By their numbers in this assay, from the lowest: compounds 1, 4, 3 and 2 (each within the scatter of the next, the first and the last beyond it).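

At this place on the five-membered aromatic ring with 2 nitrogen, this assay gives a 1.6-fold lower number from compound 2 to compound 4 (0.20 log units; within the scatter), so this position takes naphthalen-2-yl in place of 4-methoxyphenyl without a shift beyond the scatter. The change adds a second six-membered aromatic ring and removes the hydrogen-bond acceptor, yet the number stays close. Nothing available accounts for this result.

Going by these compounds, whether an amine or a carboxylic acid at this place would move the number beyond the scatter remains open. So does whether naphthalen-2-yl would behave alike on compound 3.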